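The source may hold more compounds than are shown below. What is called first, only, known or untested is meant among the compounds shown, and "the series" means these compounds.

Compound 1 `CCCCCCCCCCCCn1nnc(C(C(=O)NC(C)(C)C)c2ccccc2)n1`: 1%
Compound 2 `CCCCCCCCn1nnc(C(C(=O)Nc2c(OC)cc(OC)cc2OC)c2ccccc2)n1`: 13%

Both were tested in an assay on isolated protein for inhibition of sterol O-acyltransferase 1 (Mus musculus), tested at 0.1 uM; a higher number here means more inhibition at the concentration tested (going by the name of the read-out), a lower number less inhibition. Compound 2 gives 13%, the higher of the two numbers; compound 1 gives 1%, and the gap between them lies beyond the usual scatter. Compound 3 `C=CCCCCCCCCCn1nnc(C(C(=O)Nc2c(OC)cc(OC)cc2OC)c2ccccc2)n1` has not been measured yet. It differs from compound 2 by allyl in place of hydrogen on a saturated chain carbon, eight bonds along the chain from an aromatic nitrogen. Among the measured compounds shown here, no measured pair shows this change, so a step from compound 2 to compound 3 that stays within the usual scatter, in either direction, is expected. Compound 3 is estimated at 15%, with a range from 3% to 35%. That estimate means an expected step of a number 2 percentage points higher from compound 2 to compound 3 (within the scatter).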

Compound 3, a percentage reported as inhibition, at one concentration (the size of the read-out at that concentration, not a potency): 54%
For compound 3 the middle estimate is 39 percentage points below the measured one; the measured number lies above the stated range.
By their numbers in this assay, from the lowest: compound 1; then compound 2; then compound 3.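

In this assay, allyl in place of hydrogen on a saturated chain carbon, eight bonds along the chain from an aromatic nitrogen, gives a number 41 percentage points higher from compound 2 to compound 3 (beyond the scatter) and is a large step. The far end of this chain can therefore change the read-out strongly, which compound 1 and compound 2 could not show, as they differ in more than one place. Nothing measured here explains the step.

Going by these compounds, whether the added length or the double bond carries the step stays open; a saturated undecyl chain would separate the two, and a longer chain would show whether the rise continues.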